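The source may hold more compounds than are shown below. What is called first, only, known or untested is meant among the compounds shown, and "the series" means these compounds.

Measured compounds:
- compound 1 `O=C(CC1c2ccccc2N=C(SCCCCCN2CCCC2)N1c1ccc(-c2ccccc2)cc1)NCc1ccc(F)cc1`: in an assay on cells for inhibition of Voltage-dependent T-type calcium channel subunit alpha-1I (Homo sapiens), read by patch clamp (on this read-out lower numbers stand for stronger inhibition and higher numbers for weaker inhibition), compound 1 gives 13600 nM
- compound 2 `O=C(CC1c2ccccc2N=C(SCCCCCN2CCCC2)N1c1ccc(-c2ccc(F)cc2)cc1)NCc1ccccc1`: in this assay compound 2 gives 5100 nM

Among the compounds with values here, of the two numbers known, compound 2 holds the lower one, and the gap to compound 1 is larger than the usual scatter of this kind of measurement, so compound 2 counts as the stronger inhibitor of the pair. The two compounds do not differ in one place only: compound 1 carries its fluoro on the benzyl group attached to the amide, while compound 2 carries it on the outer ring of the biphenyl, so the gap between them cannot be tied to a single change.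

Compound 3 `O=C(CC1c2ccccc2N=C(SCCCCCN2CCCC2)N1c1ccc(-c2ccccc2)cc1)NCc1ccccc1` is not yet measured. It comes from compound 2 by the change (hydrogen in place of fluoro on an aromatic carbon), hydrogen in place of fluoro on an aromatic carbon; cut one bond further out, 4-fluorophenyl becomes phenyl. Compound 3 also matches compound 1 except for the fluoro on the benzyl group, so it sits structurally between the two measured compounds. Within the data shown here, with no single-change step available, a small weakening is expected from compound 2 to compound 3, about a 1.6-fold higher number from compound 2 to compound 3 (0.20 log units; within the scatter), close to or at the edge of the scatter. The estimate for compound 3 in this assay is 8000 nM, within a range from 3000 nM to 20000 nM.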

Compound 3, half-maximal inhibitory concentration: 810 nM
Compound 3: middle estimate off by 9.9-fold (0.99 log units), on the high side; the whole stated range lies above it.
By their numbers in this assay, from the lowest: compound 3; then compound 2; then compound 1.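

In this assay, hydrogen in place of fluoro on an aromatic carbon, where 4-fluorophenyl becomes phenyl, gives a 6.3-fold lower number from compound 2 to compound 3 (0.80 log units; beyond the scatter), and the same kind of change on the benzyl group attached to the amide gives a 17-fold lower number from compound 1 to compound 3 (1.23 log units; beyond the scatter). The first two compounds differed in two places, so neither fluoro could be judged alone; now each can be, and both steps lie beyond the scatter and point the same way, towards stronger inhibition without the fluoro. Among these three compounds, compound 3, which carries no fluoro at all, is the strongest inhibitor, so at both places the fluoro goes with weaker inhibition, not stronger.

From the compounds shown here alone, it remains open whether other groups at these two places, such as chloro, methoxy or an amine, would match the plain hydrogen of compound 3 or go beyond it, and whether the trend holds with the fluoro moved elsewhere on the same rings. Nothing shown here accounts for why removing a single fluoro changes the number this much at either place.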